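Swapping an acetylpyrazole for a tert-butylpyrazolylamino group

This account rests on a few compounds, and the source may have more. Where it says the series, first, only, none or still open, it means among the compounds named here.

- compound 1 `CC(=O)c1cc(C(=O)N[C@@H](C)Cn2ccc(-c3cc(F)c(C#N)c(Cl)c3)n2)n[nH]1`: 27700 nM
- compound 2 `CC(=O)c1cc(C(=O)N[C@H](C)Cn2ccc(-c3cc(F)c(C#N)c(Cl)c3)n2)n[nH]1`: "not determined" (no result reported)
- compound 3 `CC(O)c1ccc(C(=O)N[C@@H](C)Cn2ccc(-c3ccc(C#N)c(Cl)c3)n2)cc1`: > 30000 nM (a limit)

Within the data shown here, in an ADME assay on L02 cells (Homo sapiens) for cytotoxicity, read by CCK-8 assay, with a stated time of 6 days (on this read-out higher numbers stand for weaker inhibition and lower numbers for stronger inhibition), compound 1 gives 27700 nM, the only actual number in this small set. Compound 3 has > 30000 nM, which is a limit of the assay and not a number. Compound 2 has the entry "not determined" (no result reported), so it offers no comparison.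

Compound 4 `C[C@@H](Cn1ccc(-c2cc(F)c(C#N)c(Cl)c2)n1)NC(=O)Nc1cc(C(C)(C)C)[nH]n1` keeps much of compound 1 but carries (5-(tert-butyl)-1H-pyrazol-3-yl)amino in place of 5-acetyl-1H-pyrazol-3-yl on a carbonyl carbon. Among the measured compounds shown here, no measured pair of compounds shows what such a change does in this assay, so no step beyond the usual scatter is expected, though a slight move towards stronger inhibition is possible. The expected change is a 1.3-fold lower number from compound 1 to compound 4 (0.10 log units; within the scatter). For compound 4 the estimate is 22000 nM, with an expected range from 9000 nM to 45000 nM.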

Compound 4, half-maximal inhibitory concentration: 15000 nM
Compound 4: middle estimate off by 1.5-fold (0.17 log units), on the high side, within the range that was stated.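

In this assay, the new pair gives a 1.8-fold lower number from compound 1 to compound 4 (0.27 log units; within the scatter). Among these compounds, this is the first measured pair of compounds that differ in one place, and it shows that (5-(tert-butyl)-1H-pyrazol-3-yl)amino can replace 5-acetyl-1H-pyrazol-3-yl on this carbonyl carbon without a step beyond the usual scatter, even though the two groups differ in size and in hydrogen-bond donors and acceptors. Nothing measured here gives a cause for this small step.

As far as these compounds go, a single pair sets no trend, and whether a carboxylic acid or an amine in place of the tert-butyl group would move the number stays open. From the compounds shown here alone, the role of the configuration also stays open, as compound 2 has no reported result to set against compound 1: the fact that compounds 1 and 2 differ only in the configuration as drawn.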